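From difluorophenyl to pyridinyl on the shared core

This account rests on a few compounds, and the source may have more. Where it says the series, first, only, none or still open, it means among the compounds named here.

Measured in a functional assay on PC-3 cells (Homo sapiens) for cytotoxicity, read by WST assay, with a stated time of 72 h; on this read-out higher numbers stand for weaker inhibition and lower numbers for stronger inhibition:
- compound 1 `O=C1Nc2c(ccc(F)c2F)C1(c1ccccc1)c1ccc(O)cc1`: 8.9 nM
- compound 2 `O=C1Nc2c(ccc(F)c2F)C1(c1ccc(O)cc1)c1ccc(F)cc1`: 8.6 nM
- compound 3 `O=C1Nc2c(ccc(F)c2F)C1(c1ccc(O)cc1)c1ccc(F)c(F)c1`: 19 nM

Compound 3 carries the highest number of the three. The next structure, compound 4 `O=C1Nc2c(ccc(F)c2F)C1(c1ccncc1)c1ccc(O)cc1`, has pyridin-4-yl in place of 3,4-difluorophenyl on a saturated ring carbon. Three measured steps changed this same ring: a 1.0-fold lower number from compound 1 to compound 2 (0.01 log units; within the scatter), a 2.1-fold higher number from compound 1 to compound 3 (0.33 log units; beyond the scatter) and a 2.2-fold higher number from compound 2 to compound 3 (0.34 log units; beyond the scatter). None of them introduces a ring nitrogen, so the direction is uncertain. For the measured compounds named here, since those steps stayed small, no step clearly beyond the scatter is expected in this assay, with at most a slight lean towards a higher number. The estimated step is a 1.3-fold higher number from compound 3 to compound 4 (0.12 log units; within the scatter). For compound 4 the expected value is 25 nM, within an estimated range of 7 nM to 90 nM.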

Compound 4, half-maximal inhibitory concentration: 110 nM
Beside the measured number, compound 4's estimate is 4.4-fold (0.64 log units) below it; measured number above the stated range.
By their numbers in this assay, from the lowest: compounds 2 and 1 (each within the scatter of the next); then compound 3; then compound 4.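

In this assay this saturated ring carbon proved sensitive to the aromatic ring it carries, which the fluoro changes had not revealed: pyridin-4-yl gave a 5.8-fold higher number from compound 3 to compound 4 (0.76 log units; beyond the scatter) and a 13-fold higher number from compound 2 to compound 4 (1.11 log units; beyond the scatter) and a 12-fold higher number from compound 1 to compound 4 (1.09 log units; beyond the scatter) at this position. The last two steps are large, and the one from phenyl shows that the loss does not depend on fluoro being present in the compound it is compared with. Nothing at hand accounts for this loss.

From the compounds shown here alone, whether pyridin-3-yl or pyrimidin-5-yl would match pyridin-4-yl remains open, so the role of where the ring nitrogen sits cannot yet be told.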